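Ester exchange on a shared core: notes for compound 4

This account rests on a few compounds, and the source may have more. Where it says the series, first, only, none or still open, it means among the compounds named here.

Measured so far, all in a functional assay on MCF7 cells (Homo sapiens) for antiproliferative activity, read by MTT assay, with a stated time of 48 h; a higher number here means a weaker inhibitor, a lower number a stronger inhibitor:
compound 1 `C=C1[C@H](O)[C@@H](OC(=O)C(C)(C)C)[C@@H](O)C(C)(C)/C=C/[C@H](C)[C@H](OC(=O)c2ccccc2)[C@@]2(O)C[C@@](C)(O)[C@H](OC(C)=O)[C@@H]2[C@H]1OCC(C)C`: 69900 nM
compound 2 `C=C1[C@H](O)[C@@H](OC(=O)c2cccc(C)c2)[C@@H](O)C(C)(C)/C=C/[C@H](C)[C@H](OC(=O)c2ccccc2)[C@@]2(O)C[C@@](C)(O)[C@H](OC(C)=O)[C@@H]2[C@H]1OCC(C)C`: 63800 nM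
compound 3 `C=C1[C@H](OC(C)=O)[C@@H](OC(C)=O)[C@@H](OC(C)=O)C(C)(C)/C=C/[C@H](C)[C@H](OC(=O)c2ccccc2)[C@@]2(O)C[C@@](C)(OC(=O)C(C)(C)C)[C@H](OC(C)=O)[C@@H]2[C@H]1OCC(C)C`: > 100000 nM, a limit of the assay and not a number

Compounds 1 and 2 share a core and differ only in one ester: 3-methylphenyl in place of tert-butyl on a carbonyl carbon. That exchange gave a 1.1-fold lower number from compound 1 to compound 2 (0.04 log units; within the scatter), so the two values of compound 1 and compound 2 sit together and no order between them can be read.

Compound 3 carries the same kind of core but differs from compound 1 in more than one place; the difference between the two cores is not broken down here. For compound 3 this assay gave only a limit, (the limit of > 100000 nM in this assay, at which 1 of the 3 values shown sits).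

Compound 4 `C=C1[C@H](OC(C)=O)[C@@H](OC(C)=O)[C@@H](OC(C)=O)C(C)(C)/C=C/[C@H](C)[C@H](OC(=O)c2ccccc2)[C@@]2(O)C[C@@](C)(OC(=O)c3cccc(C)c3)[C@H](OC(C)=O)[C@@H]2[C@H]1OCC(C)C` is not yet measured. It stands to compound 3 as compound 2 stands to compound 1: 3-methylphenyl in place of tert-butyl on a carbonyl carbon. The place of the exchange is described in the same words for both pairs, so this is the same change, made a second time.

Within the data shown here, the only measured instance of this change, a 1.1-fold lower number from compound 1 to compound 2 (0.04 log units; within the scatter), stayed within the scatter. On that basis compound 4 is expected to land close to compound 3, with an estimated step that the limit leaves unreadable from compound 3 to compound 4. Since compound 3 itself gave only a limit, compound 4 is expected most likely to return a limit as well; if a number is read, it is estimated at 130000 nM, between 60000 nM and 350000 nM.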

Compound 4, half-maximal inhibitory concentration: > 100000 nM
Compound 4: a limit, no number (the forecaster's own chance of this, stated with the estimate: 70%); the middle value is on the limit's open side.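

In this assay compound 3 and compound 4 each return only a limit of the assay and not a number, so no step can be read between them: the limit of > 100000 nM in this assay, at which 2 of the 4 values shown sit.

Left open is whether 3-methylphenyl in place of tert-butyl on a carbonyl carbon shifts activity at all on the core of compound 3, as neither compound gives a readable number.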